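Replacing Chloro with Amino on a Fused Aromatic Ring

The source may report more compounds than this note shows. Statements on the series, on what has been measured and on what is new or still open speak of the compounds shown alone.

Two compounds have been measured in a functional assay on MCF7 cells (Homo sapiens) for antiproliferative activity, read by sulforhodamine B assay, with a stated time of 48 h; a lower number here means a stronger inhibitor of growth, a higher number a weaker inhibitor of growth:

Compound 1 `Nc1nn(C(=O)Nc2ccc(Cc3ccccc3)cc2)c2ccccc12`: 8820 nM
Compound 2 `Nc1nn(C(=O)Nc2ccc(Cc3ccccc3)cc2)c2ccc(Cl)cc12`: 18800 nM

Compound 2 has the higher of the two numbers, so it is the weaker growth inhibitor of the pair. Going by the values given here, the only measured step is a 2.1-fold higher number from compound 1 to compound 2 (0.33 log units; beyond the scatter), a chloro replacing a hydrogen on the fused ring; the effect was modest, though beyond the scatter.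

Compound 3 `Nc1ccc2c(c1)c(N)nn2C(=O)Nc1ccc(Cc2ccccc2)cc1` is the next compound, and its change from compound 2 is amino in place of chloro on an aromatic carbon. Among the compounds with values here, no measured step involves an amino group, so only a 2.1-fold higher number from compound 1 to compound 2 (0.33 log units; beyond the scatter) bears on it, showing that a change at this position moved the number only modestly. Amino resembles neither hydrogen nor chloro, so the direction is uncertain; compound 3 is expected to land between the two measured values, a step of a 1.7-fold lower number from compound 2 to compound 3 (0.23 log units; within the scatter).

The estimate for compound 3 in this assay is 11000 nM, within 4000 nM to 30000 nM.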

Compound 3, concentration for total growth inhibition: 26500 nM
Compound 3: middle estimate off by 2.4-fold (0.38 log units), on the low side; the measured number falls inside the stated range.
By their numbers in this assay, from the lowest: compound 1; then compounds 2 and 3 (each within the scatter of the next).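

In this assay, amino and chloro on this aromatic carbon cannot be told apart (a 1.4-fold higher number from compound 2 to compound 3 (0.15 log units; within the scatter)), even though amino carries a hydrogen-bond donor and chloro carries none. Measured against hydrogen at the same place, amino gives a 3.0-fold higher number from compound 1 to compound 3 (0.48 log units; beyond the scatter), so in these three compounds both groups tried on this carbon give a higher number than hydrogen, and neither compound goes against that. Nothing measured here gives a reason for this.

On these data alone, whether any group on this carbon can bring the number below that of compound 1 at 8820 nM stays open. The compounds shown also cannot tell how a methoxy group, a carboxylic acid or a fluoro group at this place would compare with hydrogen, chloro and amino.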